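Lengthening a Methoxy to an Ethoxy on Compound 3

The source may hold more compounds than are shown below. What is called first, only, known or untested is meant among the compounds shown, and "the series" means these compounds.

Of the compounds shown here, three sharing one core have been measured in a functional assay on thoracic aorta for antagonist activity at Alpha-1D adrenergic receptor (Rattus norvegicus); a higher number here means a more potent compound, by a factor of ten per unit of this negative logarithm, a lower number a less potent compound. Compound 1 `COc1cccc(OC)c1OCCNCCOc1ccccc1OCc1ccccc1` gives 9.37. Compound 2 `COc1cccc(OC)c1OCCNCCOc1ccccc1OCc1cccc(Cl)c1` gives 8.72, and compound 3 `COc1ccc(COc2ccccc2OCCNCCOc2c(OC)cccc2OC)cc1` gives 9.21. Compound 3 thus stands second highest of the three: it sits nearest compound 1, with a number 0.16 log units lower from compound 1 to compound 3 (within the scatter), and furthest from compound 2, with a number 0.49 log units higher from compound 2 to compound 3 (beyond the scatter).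

Compound 4 `CCOc1ccc(COc2ccccc2OCCNCCOc2c(OC)cccc2OC)cc1` has not yet been measured. It differs from compound 3 by methyl in place of hydrogen on a saturated chain carbon bound to an oxygen on an aromatic ring. Among the compounds with values here, no measured step adds a carbon to an existing group; the closest precedent is the placing of a methoxy on the same ring, a number 0.16 log units lower from compound 1 to compound 3 (within the scatter), which fell within the scatter, while the only step beyond the scatter on that ring, a number 0.65 log units lower from compound 1 to compound 2 (beyond the scatter), involved a chloro rather than a chain extension. On this basis the step from compound 3 to compound 4 is expected to be small, most likely none beyond the scatter, that is a number 0.11 log units lower from compound 3 to compound 4 (within the scatter). Compound 4 is therefore estimated to give 9.1 in this assay, between 8.6 and 9.6.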

Compound 4, negative logarithm of the antagonist equilibrium constant: 9.11
Estimate against measurement, compound 4: 0.01 log units below, within the range that was stated.
By their numbers in this assay, from the lowest: compound 2; then compounds 4, 3 and 1 (each within the scatter of the next).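

In this assay, lengthening methoxy to ethoxy gives a number 0.10 log units lower from compound 3 to compound 4 (within the scatter), so one added carbon at this place on the 4-methoxyphenyl group leaves the number unchanged within the scatter. Ethoxy in place of hydrogen gives a number 0.26 log units lower from compound 1 to compound 4 (within the scatter), so this longer group also stays within the scatter of the unsubstituted benzyl compound, while 4-ethoxyphenyl in place of 3-chlorophenyl gives a number 0.39 log units higher from compound 2 to compound 4 (beyond the scatter), which leaves compound 2 the lowest of the four. No evidence is available on why these numbers fall as they do.

As far as these compounds go, whether the number holds for a propoxy group, a longer chain or a benzyloxy group remains open, as does what an amine or a carboxylic acid at the end of that chain would do. The compounds shown also leave open how the change from methoxy to ethoxy reads at any other receptor.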